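From Isobutylamino to Pyridin-2-ylmethylamino: an Expected Cytotoxicity Value

The source may hold more compounds than are shown below. What is called first, only, known or untested is meant among the compounds shown, and "the series" means these compounds.

Compound 1, `CN(C)c1ccc2nc(-c3c(Cl)nc(N)nc3N[C@@H]3C[C@H](CO)[C@@H](O)[C@H]3O)sc2c1`: > 25000 nM
Compound 2, `Cc1nc(NCC(C)C)nc(N[C@@H]2C[C@H](CO)[C@@H](O)[C@H]2O)c1-c1nc2ccccc2s1`: 10000 nM

Of the compounds shown here, two have been measured in an ADME assay on cells (Homo sapiens) for cytotoxicity, read by polymerase chain reaction, with a stated time of 3 days; on this read-out higher numbers stand for lower toxicity in this test and lower numbers for higher toxicity in this test. Compound 2 gives 10000 nM, the only number shown in this assay. The other result, that of compound 1, is a limit of the assay rather than a number (the limit of > 25000 nM in this assay, at which 1 of the 2 values shown sits). Among the compounds with values here, compound 2 therefore stands alone as the one fixed point, and no step between two measured compounds is available.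

Compound 3, `Cc1nc(NCc2ccccn2)nc(N[C@@H]2C[C@H](CO)[C@@H](O)[C@H]2O)c1-c1nc2ccccc2s1`, has yet to be measured. It differs from compound 2 in one place: pyridin-2-yl in place of isopropyl on a saturated chain carbon bound to a nitrogen on an aromatic ring. Within the data shown here, with no measured step to draw on, the change is expected to move the result little, if at all, beyond the scatter. The expected step is a 1.2-fold higher number from compound 2 to compound 3 (0.08 log units; within the scatter). For compound 3 the estimated value in this assay is 12000 nM, with a range from 5000 nM to 30000 nM.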

Compound 3, half-maximal cytotoxic concentration: 13000 nM
Beside the measured number, compound 3's estimate is 1.1-fold (0.03 log units) below it, within the range that was stated.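

At this place, on a saturated chain carbon bound to a nitrogen on an aromatic ring, this assay records a 1.3-fold higher number from compound 2 to compound 3 (0.11 log units; within the scatter). This first step between two measured compounds shows that pyridin-2-yl, with its six-membered aromatic ring and hydrogen-bond acceptor, can replace isopropyl here with a shift that stays within the scatter. Nothing in the data shown gives a reason for this result.

On these data alone, what a carboxylic acid or a longer chain on this same carbon would do in this assay remains open. So does the comparison with phenyl at this place, which would separate the effect of the ring from that of its nitrogen.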